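Cytotoxicity of nitropyrrole thiosemicarbazides: a methyl-bearing pair

The source may report more compounds than this note shows. Statements on the series, on what has been measured and on what is new or still open speak of the compounds shown alone.

The measured compounds, each with its number in an ADME assay on Vero cells (Chlorocebus sabaeus) for cytotoxicity, read by MTT assay, with a stated time of 72 h; a higher number here means a weaker inhibitor, a lower number a stronger inhibitor:
compound 1, `COc1ccc(NC(=S)NNC(=O)c2cc([N+](=O)[O-])c[nH]2)cc1`, gives 331000 nM;
compound 2, `O=C(NNC(=S)Nc1ccccc1F)c1cc([N+](=O)[O-])c[nH]1`, gives 471000 nM;
compound 3, `COc1ccc(NC(=S)NNC(=O)c2cc([N+](=O)[O-])cn2C)cc1`, gives 184000 nM.

Compound 3 has the lowest of the three numbers in this assay. Its nearest neighbour in value is compound 1, and the gap between them, a 1.8-fold lower number from compound 1 to compound 3 (0.26 log units; within the scatter), is within the scatter; the gap to compound 2 is beyond it. Within the data shown here, the single measured step, from compound 1 to compound 3, therefore shows that adding methyl in place of hydrogen on an aromatic nitrogen changes little.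

Compound 4, `Cn1cc([N+](=O)[O-])cc1C(=O)NNC(=S)Nc1ccccc1F`, differs from compound 3 in one place: 2-fluorophenyl in place of 4-methoxyphenyl on an amide-type nitrogen. The same exchange of aryl groups separates compound 1 from compound 2, and those two values lie close together, with compound 2 the higher of the pair. Among the measured compounds shown here, no measured step covers that exchange directly, so the expectation rests on what the two values show. Compound 4 is therefore expected to give a number in this assay near that of compound 3 or somewhat higher, with a step of a 1.4-fold higher number from compound 3 to compound 4 (0.15 log units; within the scatter), and an estimate of 260000 nM, in a range from 130000 nM to 520000 nM.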

Compound 4, half-maximal inhibitory concentration: 293000 nM
For compound 4 the middle estimate is 1.1-fold (0.05 log units) below the measured one, within the range that was stated.
By their numbers in this assay, from the lowest: compounds 3, 4, 1 and 2 (each within the scatter of the next, the first and the last beyond it).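

The exchange of 4-methoxyphenyl for 2-fluorophenyl on an amide-type nitrogen can now be read directly on one core: in this assay the step is a 1.6-fold higher number from compound 3 to compound 4 (0.20 log units; within the scatter), so this exchange leaves the number within the scatter. Methyl in place of hydrogen on the aromatic nitrogen, until now seen only with 4-methoxyphenyl, can also be read with 2-fluorophenyl, as a 1.6-fold lower number from compound 2 to compound 4 (0.21 log units; within the scatter). Neither step on its own lies beyond the scatter, but the methyl change now reads alike with both aryl groups: the same change on two cores in this assay, a 1.8-fold lower number (0.26 log units; within the scatter) from compound 1 to compound 3 and a 1.6-fold lower number (0.21 log units; within the scatter) from compound 2 to compound 4, 1.1-fold (0.05 log units) apart, within the scatter of two such steps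

The compounds shown carry only two aryl groups and only hydrogen or methyl on the aromatic nitrogen, so it remains open whether an ethyl or longer chain on that nitrogen, or an aminophenyl or carboxyphenyl group in place of 2-fluorophenyl, would shift the number beyond the scatter. As far as these compounds go, all four compounds also keep the nitro group, and what a nitrile in its place would do in this assay is equally open.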